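The compounds below may be only part of what the source reports. "The series", "measured", "known", "first", "only" and "open" are said of these compounds alone.

Of the compounds shown here, two have so far been measured in a functional assay on CHOK cells for antagonist activity at growth hormone secretagogue receptor type 1 (Homo sapiens), read by calcium flux; a higher number here means a weaker inhibitor, a lower number a stronger inhibitor. Compound 1 `CCc1nc(N)nc(N)c1-c1ccc(NCc2ccc(C(C)=O)cc2)cc1` gives 110 nM in this assay. Compound 2 `N#Cc1ccc(CNc2ccc(-c3c(N)nc(N)nc3COCc3ccccc3)cc2)cc1` gives 19 nM in this assay, the lower of the two numbers, and the gap between compound 2 and compound 1 lies beyond the scatter. Among the compounds with values here, no pair of measured compounds differs in a single place, so no step can be read directly from the numbers in hand.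

Compound 3 `Nc1nc(N)c(-c2ccc(CNc3ccc([N+](=O)[O-])cc3)cc2)c(COCc2ccccc2)n1` has not yet been tested. It differs from compound 2 by ((4-nitrophenyl)amino)methyl in place of (4-cyanobenzyl)amino on an aromatic carbon, a change that swaps the nitrile for a nitro group and rebuilds the group that carries it. Within the data shown here, with no measured step to lean on, the expectation for compound 3 rests on compound 2 with its 19 nM and on the size of that change. The expected step is a 2.6-fold higher number from compound 2 to compound 3 (0.42 log units; beyond the scatter), a rise in this assay of a size only a little beyond the scatter. Compound 3 is therefore estimated at 50 nM in this assay, with a range from 12 nM to 250 nM.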

Compound 3, half-maximal inhibitory concentration: 16 nM
Estimate against measurement, compound 3: 3.1-fold (0.49 log units) above; the range from low to high includes it.
By their numbers in this assay, from the lowest: compounds 3 and 2 (each within the scatter of the next); then compound 1.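

Across this assay, replacing (4-cyanobenzyl)amino with ((4-nitrophenyl)amino)methyl on an aromatic carbon, para to a large group, gives a 1.2-fold lower number from compound 2 to compound 3 (0.07 log units; within the scatter). Within the data shown here, this is the first step that can be read at this position, and it shows that the position accepts the rebuilt group, with a nitro group in place of the nitrile, without a shift in the number beyond the scatter. Nothing in the data on hand accounts for this result.

The nitro group and the rebuilt group that carries it enter together in this single step, so the compounds shown do not separate what either change does alone. They also leave open whether the same holds for other groups at this place, such as a carboxylic acid or a trifluoromethyl group on the outer ring, or a longer chain joining that ring to the nitrogen.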